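This account rests on a few compounds, and the source may have more. Where it says the series, first, only, none or still open, it means among the compounds named here.

Compound 2 `COc1ccc(C2CC(c3ccccc3)=NN2C2=NC(=O)/C(=C3\C(=O)Nc4ccccc43)S2)cc1` and compound 1 `O=C1N=C(N2N=C(c3ccccc3)CC2c2ccccc2O)S/C1=C1/C(=O)Nc2ccccc21` share one core and differ only in the aryl group that sits on a saturated ring carbon. In a functional assay on cells (Cancer cell lines, Homo sapiens) for cytotoxicity, read by sulforhodamine B assay, with a stated time of 48 h (on this read-out higher numbers stand for weaker inhibition of growth and lower numbers for stronger inhibition of growth), compound 1 gives 36600 nM, and in the same test compound 2 gives 19000 nM. Among the compounds with values here, the only measured step, a 1.9-fold lower number from compound 1 to compound 2 (0.28 log units; within the scatter), lies within the scatter, so the two numbers cannot be told apart, and compound 2 stands alongside compound 1 at one and the same level as far as these data reach.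

Compound 3 `O=C1N=C(N2N=C(c3ccccc3)CC2c2ccc(Cl)cc2)S/C1=C1/C(=O)Nc2ccccc21` has not yet been measured. It differs from compound 2 by chloro in place of methoxy on an aromatic carbon. Within the data shown here, the one measured step bears on this change because a 1.9-fold lower number from compound 1 to compound 2 (0.28 log units; within the scatter) also exchanged the substituent on that same aryl group, and that exchange left the number where it was. On that basis the expected step is a 1.2-fold lower number from compound 2 to compound 3 (0.07 log units; within the scatter), nothing beyond the scatter. Compound 3 is therefore expected to give about 16000 nM in this assay, with a likely range from 6000 nM to 40000 nM.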

Compound 3, concentration for total growth inhibition: 650 nM
Beside the measured number, compound 3's estimate is 25-fold (1.39 log units) above it; measured number below the stated range.
By their numbers in this assay, from the lowest: compound 3; then compounds 2 and 1 (each within the scatter of the next).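

This position turns out to be far more sensitive than the first pair suggested: going from 4-methoxyphenyl to 4-chlorophenyl in this assay gives a 29-fold lower number from compound 2 to compound 3 (1.47 log units; beyond the scatter), although only a single chlorine enters where a methoxy group of two heavy atoms leaves. The 4-chlorophenyl group also separates clearly from the 2-hydroxyphenyl group, with a 56-fold lower number from compound 1 to compound 3 (1.75 log units; beyond the scatter), so the earlier impression of a flat position came from the particular pair of aryl groups then at hand, and the chloro compound now stands clearly apart from both. No measurement here offers a reason for this large change in growth inhibition.

The compounds shown leave open whether the gain belongs to chlorine in particular or would also appear with fluoro, bromo, methyl or an unsubstituted phenyl at the same place. They also leave open whether chloro would hold this level on another carbon of the ring, and whether an amine or a carboxylic acid on that aromatic ring would keep any of it.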